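The source may hold more compounds than are shown below. What is called first, only, known or untested is meant among the compounds shown, and "the series" means these compounds.

In a functional assay on T47D cells (Homo sapiens) for inhibition, read by sulforhodamine B assay, with a stated time of 48 h, tested at 10 uM (on this read-out higher numbers stand for a weaker effect at the one concentration tested and lower numbers for a stronger effect), compound 2 `COc1cc2cc(Oc3ccc(NC(=O)Nc4ccc(C)cc4)cc3)c(C)nc2cc1OC` stands at 101%, a number that sits within the usual scatter of compound 1 `COc1cc2cc(Oc3ccc(NC(=O)Nc4ccccc4)cc3)c(C)nc2cc1OC`, which gives 97.1%; both show hardly any effect at the tested concentration. Compound 3 `COc1cc2cc(Oc3ccc(NC(=O)Nc4ccc(C(F)(F)F)cc4)cc3)c(C)nc2cc1OC` differs from compound 2 by trifluoromethyl in place of methyl on an aromatic carbon. Among the compounds with values here, no measured step exchanges these two groups. Within the data shown here, the only measured step, methyl in place of hydrogen on an aromatic carbon, a number 3.9 percentage points higher from compound 1 to compound 2 (within the scatter), stayed within the scatter. A step of a number 4 percentage points lower from compound 2 to compound 3 (within the scatter) is therefore expected, nothing beyond the scatter. Compound 3 is estimated at 97%, ranging from 80% to 106%.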

Compound 3, a percentage reported as activity, at one concentration (the size of the read-out at that concentration, not a potency): 57.5%
The estimate for compound 3 lay 39.5 percentage points above the measured number; measured number below the stated range.
By their numbers in this assay, from the lowest: compound 3; then compounds 1 and 2 (each within the scatter of the next).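

In this assay, hydrogen and methyl gave values within the scatter of each other at this position, but trifluoromethyl brings a much stronger effect: a number 43.5 percentage points lower from compound 2 to compound 3 (beyond the scatter), and a number 39.6 percentage points lower from compound 1 to compound 3 (beyond the scatter). The position, on a six-membered aromatic ring of carbon only and para to a large group, therefore does respond to what sits there. Nothing available explains why trifluoromethyl differs from methyl here. Still open, from the compounds shown here alone, is whether a chlorine atom, a methoxy group or an amine at this position would behave like trifluoromethyl or like methyl.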